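This account rests on a few compounds, and the source may have more. Where it says the series, first, only, none or still open, it means among the compounds named here.

Working notes on the series. Among the compounds with values here, the shared core of compound 2, `COC(=O)/C=C/c1cccc(N(Cc2ccc(/C=C/c3ccccc3F)cc2)C(=O)C2CCCCC2)c1`, carries a cyclohexyl on the carbonyl carbon; in an assay on isolated protein with Bile acid receptor (Homo sapiens) as the target (a lower number here means that less compound is needed, a higher number that more compound is needed for the effect), compound 2 gives 64 nM, the lowest of the three numbers measured so far. Compound 1, `COC(=O)/C=C/c1cccc(N(Cc2ccc(/C=C/c3c(F)cccc3F)cc2)C(=O)C(C)C)c1`, gives 108 nM in this assay, a difference from compound 2 that stays within the scatter; the two differ in more than one place, so nothing further is drawn from that pair. Within the data shown here, compound 3, `COC(=O)/C=C/c1cccc(N(Cc2ccc(/C=C/c3ccccc3F)cc2)C(=O)NC(C)C)c1`, gives 431 nM in this assay, and the one clean step measured so far, a 6.7-fold higher number from compound 2 to compound 3 (0.83 log units; beyond the scatter), concerns the group on the carbonyl carbon only.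

Compound 4, `COC(=O)/C=C/c1cccc(N(Cc2ccc(/C=C/c3cccc(F)c3)cc2)C(=O)C2CCCCC2)c1`, is not yet measured. It differs from compound 2 as 3-fluorophenyl in place of 2-fluorophenyl on a double-bonded chain carbon bound to a double-bonded chain carbon, with the cyclohexyl kept. Among the measured compounds shown here, no measured step touches the fluorine position on the ring at the end of the double-bonded chain, so the step from compound 2 to compound 3 does not bear on this change, and no direction can be derived from the data. The expectation is therefore a step of a 1.3-fold higher number from compound 2 to compound 4 (0.10 log units; within the scatter), close to no change beyond the scatter. Compound 4 is estimated at 80 nM in this assay, with a range from 25 nM to 260 nM.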

Compound 4, half-maximal effective concentration: 86 nM
Compound 4: the middle estimate sits 1.1-fold (0.03 log units) below what was measured; measured number inside the range.
By their numbers in this assay, from the lowest: compounds 2, 4 and 1 (each within the scatter of the next); then compound 3.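

Within the data shown here, with the cyclohexyl kept, 3-fluorophenyl in place of 2-fluorophenyl on a double-bonded chain carbon bound to a double-bonded chain carbon gives in this assay a 1.3-fold higher number from compound 2 to compound 4 (0.13 log units; within the scatter), the first clean reading at this end of the molecule. Among these compounds, this step stays within the scatter, so the two fluorophenyl groups cannot be told apart here, whereas the one earlier clean step, a 6.7-fold higher number from compound 2 to compound 3 (0.83 log units; beyond the scatter), lies beyond the scatter and concerns the group on the carbonyl carbon. Nothing at hand bears on why the two fluorophenyl groups read alike.

Open is whether this tolerance extends beyond a shift of the fluorine, since the compounds shown do not tell how a plain phenyl, a chlorophenyl or a methoxyphenyl would read at this place. Also open, on these data alone, are the effect of the second fluorine on the ring of compound 1, whose step cannot be read because that compound differs from the others in more than one place, and whether the step seen with isopropylamino would recur with 3-fluorophenyl.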